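Swapping the Aryl Group on the Amide Carbonyl

The compounds below may be only part of what the source reports. "The series", "measured", "known", "first", "only" and "open" are said of these compounds alone.

Compound 2 `O=C(Nc1cccc(-c2oc3cc(-c4ccc(F)cc4)ccc3c(=O)c2O)c1)c1ccc(Cl)nc1` gives 4080 nM in a functional assay on HeLa cells (Homo sapiens) for antiproliferative activity, read by CCK-8 assay, with a stated time of 72 h (on this read-out higher numbers stand for weaker inhibition and lower numbers for stronger inhibition), the lower of the two numbers shown, although compound 1 `O=C(Nc1cccc(-c2oc3cc(-c4ccc(F)cc4)ccc3c(=O)c2O)c1)c1ccc(F)cc1`, which gives 5350 nM in this assay, lies within the scatter of it: the step from compound 1 to compound 2 was a 1.3-fold lower number from compound 1 to compound 2 (0.12 log units; within the scatter). Compound 3 `O=C(Nc1cccc(-c2oc3cc(-c4ccc(F)cc4)ccc3c(=O)c2O)c1)c1cc(F)cc(F)c1` differs from compound 2 by 3,5-difluorophenyl in place of 6-chloropyridin-3-yl on a carbonyl carbon. Among the measured compounds shown here, the only measured step bearing on this change, the exchange of the group on the carbonyl carbon, stayed within the scatter, so no shift beyond the scatter is expected here either. Compound 3 is therefore expected to give about 4500 nM, between 2000 nM and 10000 nM, an expected step of a 1.1-fold higher number from compound 2 to compound 3 (0.04 log units; within the scatter).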

Compound 3, half-maximal inhibitory concentration: 3380 nM
Compound 3: the middle estimate sits 1.3-fold (0.12 log units) above what was measured, within the range that was stated.
By their numbers in this assay, from the lowest: compounds 3, 2 and 1 (each within the scatter of the next).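

In this assay, the exchange on the carbonyl carbon now covers a third aromatic ring, 3,5-difluorophenyl, a ring of carbon only, and the steps stay small: a 1.2-fold lower number from compound 2 to compound 3 (0.08 log units; within the scatter) and a 1.6-fold lower number from compound 1 to compound 3 (0.20 log units; within the scatter). The three groups cannot be told apart at this place, whether or not the ring holds a nitrogen. No measurement at hand offers a reason for this. On these data alone, whether a ring carrying an amine or a carboxylic acid, or a plain alkyl chain, would move the number beyond the scatter stays open. As far as these compounds go, the effect of changes elsewhere on the shared core also stays open.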